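Methoxy on the aryl ring: expectation for compound 3

This account rests on a few compounds, and the source may have more. Where it says the series, first, only, none or still open, it means among the compounds named here.

Among the compounds with values here, compound 1 `N#CC1=C(N)N(c2ccc(S(N)(=O)=O)cc2)C2=C(C(=O)CCC2)C1c1ccccc1` and compound 2 `N#CC1=C(N)N(c2ccc(S(N)(=O)=O)cc2)C2=C(C(=O)CCC2)C1/C=C/c1ccccc1` are the two measured members of this set. In a functional assay on Ehrlich cells (Mus musculus) for antiproliferative activity, read by trypan blue exclusion, with a stated time of 2 h, tested at 50 ug/mL (on this read-out higher numbers stand for a stronger effect at the one concentration tested and lower numbers for a weaker effect), compound 1 gives 40%, and compound 2 gives 40%. Within the data shown here, the one measured step, no change at the digits printed from compound 1 to compound 2 (within the scatter), changes 2-phenylethenyl for phenyl on a saturated ring carbon and leaves the read-out unchanged within the scatter, so compound 1 stands level with compound 2 and nothing in the measured pair separates them.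

Compound 3 `COc1ccc(C2C(C#N)=C(N)N(c3ccc(S(N)(=O)=O)cc3)C3=C2C(=O)CCC3)cc1` is the next candidate. It differs from compound 1 by methoxy in place of hydrogen on an aromatic carbon. Among the measured compounds shown here, no measured step touches this aromatic ring itself; the only step on record, from phenyl to 2-phenylethenyl on the saturated ring carbon, bears on the same region and was flat. With the substituent on the aromatic ring varied without effect once, the step to compound 3 is expected to be small as well.

For compound 3 the expected step of no change at the digits printed from compound 1 to compound 3 (within the scatter) is therefore no change beyond the scatter, and the estimated activity of compound 3 is 40%, with a range from 25% to 55%.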

Compound 3, a percentage reported as activity, at one concentration (the size of the read-out at that concentration, not a potency): 90%
Estimate against measurement, compound 3: 50 percentage points below, and the stated range ends below it.
By their numbers in this assay, from the lowest: compounds 1 and 2 (each within the scatter of the next); then compound 3.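

The aromatic ring on the saturated ring carbon of the core of compound 1 is sensitive to substitution in this assay: methoxy in place of hydrogen on an aromatic carbon, para to a large group, gives a number 50 percentage points higher from compound 1 to compound 3 (beyond the scatter) and sets this change well apart from the earlier replacement of phenyl by 2-phenylethenyl. The flat step, no change at the digits printed from compound 1 to compound 2 (within the scatter), therefore did not show that this region tolerates any change without effect, since 4-methoxyphenyl in place of 2-phenylethenyl on the same saturated ring carbon gives a number 50 percentage points higher from compound 2 to compound 3 (beyond the scatter) and separates compound 3 from both earlier compounds. No supporting data are available to explain this rise in activity.

The compounds shown leave open whether the rise is specific to methoxy or would also appear with a hydroxy group, an ethoxy group, a chlorine atom or a dimethylamino group at the same place on the ring. They also leave open how compound 3 would behave across a range of concentrations, as each read-out here gives the size of the effect at one concentration and not a potency.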